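The source may hold more compounds than are shown below. What is called first, only, known or untested is meant among the compounds shown, and "the series" means these compounds.

Measured compounds:
compound 1 `O=C1CSC(c2c(Cl)cccc2Cl)N1CCN1CCCCC1` gives 100%
compound 2 `O=C1CSC(c2cccc(Cl)c2)N1CCN1CCCCC1` gives 100%
compound 3 `O=C1CSC(c2ccc(O)cc2)N1CCN1CCCCC1` gives 96%

These three share one core and differ only in the aromatic ring attached to a saturated ring carbon. All were tested in an ADME assay on Vero cells (Chlorocebus sabaeus) for cytotoxicity, read by neutral red uptake, tested at 49 ug/mL; a higher number here means a weaker effect of the compound at the concentration tested, a lower number a stronger effect. Compound 1 stands level with compound 2 at the digits shown, and the two together are the highest of the three numbers; compound 3 lies a little lower, yet the step of a number 4 percentage points lower from compound 2 to compound 3 (within the scatter) is within the scatter, so none of the three can really be told apart.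

Compound 4 `O=C1CSC(c2ccccc2Cl)N1CCN1CCCCC1` has not yet been measured. It differs from compound 1 in one place: hydrogen in place of chloro on an aromatic carbon. Among the compounds with values here, the only step available for comparison, a number 4 percentage points lower from compound 2 to compound 3 (within the scatter), exchanged an entire aromatic substituent and still moved nothing beyond the scatter; removing a single chloro group from the same ring is a smaller alteration, so no movement beyond the scatter is expected in this assay. Compound 4 is therefore estimated at 98%, between 85% and 100%, and the expected step of a number 2 percentage points lower from compound 1 to compound 4 (within the scatter) is essentially none.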

Compound 4, a percentage reported as activity, at one concentration (the size of the read-out at that concentration, not a potency): 100%
Compound 4: the middle estimate sits 2 percentage points below what was measured; low and high end bracket the measured number.
By their numbers in this assay, from the lowest: compounds 3, 1, 2 and 4 (each within the scatter of the next).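

In this assay, taking one chloro group off the aromatic ring and leaving hydrogen in its place gives a step that stays within the scatter (no change at the digits printed from compound 1 to compound 4 (within the scatter)), so this position, ortho to a large group and meta to a chloro group, tolerates losing that single atom in this read-out. The other two steps stay within the scatter as well: 2-chlorophenyl in place of 3-chlorophenyl (no change at the digits printed from compound 2 to compound 4 (within the scatter)) and 2-chlorophenyl in place of 4-hydroxyphenyl (a number 4 percentage points higher from compound 3 to compound 4 (within the scatter)), so compound 4 cannot be told apart from compound 1, compound 2 or compound 3. Nothing available explains why these changes leave the read-out so flat.

From the compounds shown here alone, whether an amine, a carboxylic acid or a longer chain on this aromatic ring would move the number beyond the scatter remains open. So does the effect of any change elsewhere in the shared core.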